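Saccharin-type acyl series: stability half-life notes

The source may hold more compounds than are shown below. What is called first, only, known or untested is meant among the compounds shown, and "the series" means these compounds.

Measured compounds:
- compound 1 `O=C(NCc1ccccc1Br)N1C(=O)c2ccccc2S1(=O)=O`: > 166 h
- compound 2 `O=C(CCc1ccccc1)N1C(=O)c2ccccc2S1(=O)=O`: > 166 h
- compound 3 `O=C(c1ccccc1)N1Cc2ccccc2S1(=O)=O`: > 166 h

In a physicochemical assay for pharmacokinetics (on this read-out higher numbers stand for a longer-lived compound and lower numbers for a shorter-lived compound), compound 1 gives only a limit, > 166 h, not a number. Compound 2 likewise reaches only the limit. Compound 3 also stops at the limit. Across the set this is summed up by the limit of > 166 h in this assay, at which 3 of the 3 values shown sit. No pair of these compounds differs in a single place, so no measured step is available.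

Compound 4 `COc1cccc(CNC(=O)N2C(=O)c3ccccc3S2(=O)=O)c1` is the next candidate. Its change from compound 1 is 3-methoxyphenyl in place of 2-bromophenyl on a saturated chain carbon bound to an amide-type nitrogen. Among the measured compounds shown here, with every value so far sitting at the limit, no step beyond the scatter is expected; a number no higher from compound 1 to compound 4 (the limit leaves the size open) is estimated to be essentially flat. Compound 4 is expected to give 166 h in this assay, within 90 h to 166 h, most likely again reported only as the limit.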

Compound 4, half-life: > 166 h
Compound 4: no number, only a limit; the forecaster's own chance of this, stated with the estimate: 80%; the middle value sits exactly at the limit.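

No step can be read between compound 1 and compound 4; both values are limits, not numbers. The compounds shown leave open the actual half-life of each compound in this assay, and whether 3-methoxyphenyl and 2-bromophenyl differ at all.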